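The source may report more compounds than this note shows. Statements on the series, on what has been measured and on what is new or still open speak of the compounds shown alone.

Measured compounds in a functional assay on A-375 cells (Homo sapiens) for antiproliferative activity, read by MTT assay, with a stated time of 24 h; a higher number here means a weaker inhibitor, a lower number a stronger inhibitor:
- compound 1, `C=CCOc1ccc2c(=O)c(-c3cc(OC)c(OC)cc3OC)coc2c1`, gives 4750 nM
- compound 2, `COc1cc(OC)c(-c2coc3cc(OCc4ccccc4)ccc3c2=O)cc1OC`, gives 1640 nM
- compound 3, `COc1cc(OC)c(-c2coc3cc(OCc4ccccc4C(F)(F)F)ccc3c2=O)cc1OC`, sits at > 10000 nM

For compound 3 that entry is a limit of the assay and not a number (the limit of > 10000 nM in this assay, at which 1 of the 3 values shown sits). Among the two numbers, compound 2 stands lowest: a 2.9-fold lower number from compound 1 to compound 2 (0.46 log units; beyond the scatter).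

Compound 4, `COc1cc(OC)c(-c2coc3cc(OCc4ccc(Cl)cc4)ccc3c2=O)cc1OC`, is not yet measured in this assay. Its difference from compound 2 is chloro in place of hydrogen on an aromatic carbon. Within the data shown here, the only measured step that puts a substituent onto this same ring is an at least 6.0-fold higher number from compound 2 to compound 3 (0.78 log units; beyond the scatter), and its partner from the other side is an at least 2.1-fold higher number from compound 1 to compound 3 (0.32 log units; beyond the scatter); in both cases the entering group is trifluoromethyl and the ring becomes 2-(trifluoromethyl)phenyl, whereas the chloro of compound 4 sits para to a large group. Among the measured compounds shown here, no measured pair shows chloro in place of hydrogen, so the precedent is indirect. Given that the one substitution on this ring moved the number beyond the limit, a step toward a higher number is the more likely direction, but a chloro at a different place is expected to give a smaller step, possibly within the scatter. The expected step is a 1.4-fold higher number from compound 2 to compound 4 (0.15 log units; within the scatter). Compound 4 is therefore estimated at 2300 nM, with a range from 900 nM to 7000 nM.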

Compound 4, half-maximal inhibitory concentration: 1020 nM
The estimate for compound 4 lay 2.3-fold (0.35 log units) above the measured number, and the stated range covers the measured number.
By their numbers in this assay, from the lowest: compounds 4 and 2 (each within the scatter of the next); then compound 1. At a limit, above all of these: compound 3.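

In this assay, chloro in place of hydrogen on an aromatic carbon, para to a large group, gives a 1.6-fold lower number from compound 2 to compound 4 (0.21 log units; within the scatter), so compound 2 and compound 4 cannot be told apart, and the 4-chlorobenzyl group keeps the standing that the benzyl group has against the vinyl-bearing chain, with a 4.7-fold lower number from compound 1 to compound 4 (0.67 log units; beyond the scatter). Substitution on this ring therefore does not go with a loss in every case, since the other listed step between the substituted rings reads an at least 9.8-fold lower number from compound 3 to compound 4 (0.99 log units; beyond the scatter). The entry for compound 3 in that step is a limit of the assay and not a number: the limit of > 10000 nM in this assay, at which 1 of the 4 values shown sits.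

On these data alone, whether the gap between compound 3 and compound 4 follows the entering group or its place on the ring stays open, with trifluoromethyl and chloro seen only at different places. As far as these compounds go, how this ring would read with an amine or a carboxylic acid at the place of the chloro also remains open, as does whether any such group would give a step beyond the scatter from compound 2.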